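The source may report more compounds than this note shows. Statements on the series, on what has been measured and on what is new or still open speak of the compounds shown alone.

Measured compounds:
- compound 1 `O=S(=O)(Nc1ccc(-c2nc3ccccc3o2)cc1)c1ccc(F)cc1`: > 63000 nM
- compound 2 `O=S(=O)(Nc1ccc(-c2nc3ccccc3o2)cc1)c1ccc(Cl)cc1`: > 63000 nM
- compound 3 `Cc1ccc(S(=O)(=O)Nc2ccc(-c3nc4ccccc4o3)cc2)cc1`: > 63000 nM

In an assay on isolated protein for inhibition of malate dehydrogenase, mitochondrial (Sus scrofa), with stated times of 45 min and 30 min (a higher number here means a weaker inhibitor, a lower number a stronger inhibitor), compound 1 reaches only the limit of the assay, > 63000 nM, not a number. Compound 2 likewise sits at the limit, > 63000 nM, in this assay. Compound 3 too gives only the limit, > 63000 nM, in this assay. All three values are at the same limit, (the limit of > 63000 nM in this assay, at which 3 of the 3 values shown sit), so no order among compounds 1, 2 and 3 can be read.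

The steps between the measured compounds are therefore all unreadable: a step that the two limits leave unreadable from compound 1 to compound 2, a step that the two limits leave unreadable from compound 1 to compound 3 and a step that the two limits leave unreadable from compound 2 to compound 3. None of them gives a size in either direction.

Compound 4 `O=S(=O)(Nc1ccc(-c2nc3ccccc3o2)cc1)c1ccc(Cl)c(Cl)c1` has not yet been measured in this assay. It differs from compound 3 by 3,4-dichlorophenyl in place of 4-methylphenyl on a sulfonyl sulfur. The measured steps on this aromatic ring, each between a fluoro, chloro or methyl group, were all hidden by the limit, so they give no basis for a readable step in this assay, and none beyond the scatter is expected from a step that the limit leaves unreadable from compound 3 to compound 4. Compound 4 is therefore expected to give about 80000 nM in this assay, in the range 20000 nM to 300000 nM, most likely again as a limit rather than a number.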

Compound 4, half-maximal inhibitory concentration: > 63000 nM
Compound 4 gave a limit, no number (the forecaster's own chance of this, stated with the estimate: 75%); the middle value does not contradict the limit.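

The steps from compound 1, compound 2 and compound 3 to compound 4 cannot be read in this assay, since each value is a limit and not a number: the limit of > 63000 nM in this assay, at which 4 of the 4 values shown sit. The compounds shown leave open whether any group on the sulfonyl sulfur gives a measurable inhibition, and how these four compounds rank.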